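Swapping 4-methoxyphenyl for 3-methylphenyl on the shared core

This account rests on a few compounds, and the source may have more. Where it says the series, first, only, none or still open, it means among the compounds named here.

Measured compounds:
Compound 1: `CCSc1sc(-n2nc(C)c(Cc3ccccc3[N+](=O)[O-])c2C(=O)O)nc1-c1ccc(Cl)c(Cl)c1` — compound 1 gives 59000 nM
Compound 2: `COc1ccc(-c2c(C)nn(-c3nc(-c4ccc(Cl)c(Cl)c4)c(SC(C)C)s3)c2C(=O)O)cc1` — compound 2 gives 2100 nM

Both numbers come from a functional assay on BJAB cells (Homo sapiens) for antiproliferative activity, with a stated time of 4 days; a higher number here means that more compound is needed for the effect, a lower number that less compound is needed. Compound 2 stands at the lowest number of the two; compound 1 sits far higher, a gap well beyond the usual scatter of this assay. The two differ in more than one place, so nothing can be said about which part of the structure drives that gap.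

Compound 3, `Cc1cccc(-c2c(C)nn(-c3nc(-c4ccc(Cl)c(Cl)c4)c(SC(C)C)s3)c2C(=O)O)c1`, has not yet been measured. It differs from compound 2 in a single way: 3-methylphenyl in place of 4-methoxyphenyl on an aromatic carbon. For the measured compounds named here, no pair of measured compounds differs in only one place, so there is no step to lean on for this kind of change. Given that the group leaving and the group entering are of similar size, the step of a 1.7-fold higher number from compound 2 to compound 3 (0.22 log units; within the scatter) is expected to be small, within or only slightly beyond the scatter, most likely toward a somewhat higher number. Compound 3 is therefore estimated to give about 3500 nM, with a plausible range from 900 nM to 14000 nM.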

Compound 3, half-maximal effective concentration: 17000 nM
The estimate for compound 3 lay 4.9-fold (0.69 log units) below the measured number, and the stated range ends below it.
By their numbers in this assay, from the lowest: compound 2; then compound 3; then compound 1.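

In this assay, for the compounds shown here, the exchange of 4-methoxyphenyl for 3-methylphenyl on this aromatic carbon gives an 8.1-fold higher number from compound 2 to compound 3 (0.91 log units; beyond the scatter) and is the first change on the shared core that can be read on its own. Both groups hold one six-membered aromatic ring of carbon only, and they differ little in heavy-atom count, yet the step lies beyond the scatter, so this position does not treat two such similar-looking groups as interchangeable. The compounds shown offer no measurement that explains the step.

The exchange alters two things at once, the group carried on the phenyl ring and the place it occupies there, and this single step cannot separate the two. Also open, as far as these compounds go, is how this position responds to an unsubstituted phenyl ring, or to a phenyl ring carrying an amine or a carboxylic acid, and whether the same exchange would give a step of similar size with a thioether other than the isopropyl one on the shared core.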